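This account rests on a few compounds, and the source may have more. Where it says the series, first, only, none or still open, it means among the compounds named here.

Measured so far in an ADME assay on microsomes from liver (Rattus norvegicus) for metabolic stability, with a stated time of 10 min; on this read-out lower numbers stand for a less stable compound and higher numbers for a more stable compound:
- compound 1 `COc1ccc(Nc2nc(Cl)cn([C@H](C)C3CC3)c2=O)c(OC)n1`: 43%
- compound 2 `Cc1cc(Nc2nc(Cl)cn([C@H](C)C3CC3)c2=O)c(C)nc1N(C)C`: 54%
- compound 3 `Cc1nc(C(F)(F)F)ccc1Nc1nc(Cl)cn([C@H](C)C2CC2)c1=O`: "not determined" (no result reported)

Of the two numbers available, the higher belongs to compound 2 at 54%, and the gap down to compound 1 at 43% lies beyond the usual scatter. Compound 3 gives no number to compare. Compound 4 `Cc1cc(Nc2nc(Cl)cn([C@H](C)C3CC3)c2=O)c(C)nc1OC(F)F` has not yet been measured. It carries difluoromethoxy in place of dimethylamino on an aromatic carbon. Among the measured compounds shown here, no two measured compounds differ in one place alone, so this estimate is only a cautious one. In this assay the expected step is a number 6 percentage points higher from compound 2 to compound 4 (within the scatter), a small rise that stays within the scatter. For compound 4 the estimated value is 60%, with an expected range from 40% to 80%.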

Compound 4, percent of the compound remaining: 100%
For compound 4 the middle estimate is 40 percentage points below the measured one, and the stated range ends below it.
By their numbers in this assay, from the lowest: compound 1; then compound 2; then compound 4.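

In this assay, difluoromethoxy in place of dimethylamino next to the ring nitrogen gives a number 46 percentage points higher from compound 2 to compound 4 (beyond the scatter), and this is the only pair shown that differs in one place. It shows that changing this single group, with the rest of the compound unchanged, can shift the read-out by a large step beyond the scatter. No measurement shown here accounts for the size of this step. From the compounds shown here alone, whether methoxy or trifluoromethoxy at this position would give a similar result remains open. Going by these compounds, it is also open whether the same change would have a comparable effect on another compound.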